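From an Amine Arm to an Ethylcarbamoyl Group

The source may report more compounds than this note shows. Statements on the series, on what has been measured and on what is new or still open speak of the compounds shown alone.

Of the compounds shown here, three sharing one core have been measured in a functional assay on HCT-116 cells (Homo sapiens) for inhibition; on this read-out higher numbers stand for weaker inhibition and lower numbers for stronger inhibition. Compound 1 `CCNC(=O)c1noc(-c2cc(C(C)C)c(O)cc2O)c1-c1cc(COCC(N)=O)no1` gives 97 nM. Compound 2 `CCNC(=O)c1noc(-c2cc(C(C)C)c(O)cc2O)c1-c1cc(CNC(C)C)no1` gives 109 nM, close to compound 1: the step of a 1.1-fold higher number from compound 1 to compound 2 (0.05 log units; within the scatter) lies within the scatter. Compound 3 `CCNC(=O)c1noc(-c2cc(C(C)C)c(O)cc2O)c1-c1cc(CN2CCN(C)CC2)no1` gives 340 nM, and the steps of a 3.5-fold higher number from compound 1 to compound 3 (0.54 log units; beyond the scatter) and a 3.1-fold higher number from compound 2 to compound 3 (0.49 log units; beyond the scatter) are modest but beyond the scatter. Compound 2 thus stands between the other two, with compound 1 close by and compound 3 further off at a higher number.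

Compound 4 `CCNC(=O)c1cc(-c2c(C(=O)NCC)noc2-c2cc(C(C)C)c(O)cc2O)on1` has not yet been measured. It differs from compound 2 in one place: ethylcarbamoyl in place of (isopropylamino)methyl on an aromatic carbon. Cut one bond further out, the change reads 3-((isopropylamino)methyl)-1,2-oxazol-5-yl to 3-(ethylcarbamoyl)-1,2-oxazol-5-yl. Within the data shown here, none of the measured steps exchanges this whole arm; they only vary the group on the saturated chain carbon, and those variations move the number within a modest range. The change in compound 4 is of a different kind, so a modest step in either direction in this assay seems possible, with no firm lean. The expected value for compound 4 is 150 nM, between 50 nM and 450 nM, which means an estimated step of a 1.4-fold higher number from compound 2 to compound 4 (0.14 log units; within the scatter).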

Compound 4, half-maximal inhibitory concentration: 14 nM
The estimate for compound 4 lay 11-fold (1.03 log units) above the measured number; measured number below the stated range.
By their numbers in this assay, from the lowest: compound 4; then compounds 1 and 2 (each within the scatter of the next); then compound 3.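

The earlier compounds shown here varied only the group on the saturated chain carbon, and those changes stayed modest at most in this assay. Replacing the whole arm with ethylcarbamoyl on the aromatic carbon next to the ring nitrogen gives a 7.8-fold lower number from compound 2 to compound 4 (0.89 log units; beyond the scatter), together with a 6.9-fold lower number from compound 1 to compound 4 (0.84 log units; beyond the scatter) and a 24-fold lower number from compound 3 to compound 4 (1.39 log units; beyond the scatter), so this position tolerates more than an amine or ether arm, and compound 4 has the lowest number of the four. The leaving (isopropylamino)methyl and the entering ethylcarbamoyl match in heavy atoms, hydrogen-bond donors and hydrogen-bond acceptors, so those counts do not separate compound 2 from compound 4, and nothing shown here explains the difference.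

On these data alone, it remains open whether the lower number depends on the carbonyl sitting directly on the aromatic carbon or also on the ethyl end of the amide. A methylcarbamoyl, a propylcarbamoyl or a carboxylic acid on this same carbon would help separate these two parts of the group, and an ethylaminomethyl arm would show what the carbonyl itself contributes.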